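The compounds below may be only part of what the source reports. "The series", "measured", "known", "first", "only" and "open" are said of these compounds alone.

Measured compounds:
- compound 1 `NS(=O)(=O)c1ccc(-c2nc(C(c3ccc(F)cc3)c3ccc(F)cc3)sc2CC(=O)O)cc1`: 1500 nM
- compound 2 `O=C(O)Cc1sc(C(c2ccccc2)c2ccc(F)c(F)c2)nc1-c1ccc(F)cc1`: 10 nM
- compound 3 `O=C(O)Cc1sc(C(c2ccccc2)c2ccccn2)nc1-c1ccc(Cl)cc1`: 810 nM

In an in vitro assay on HEK385-7 cells for displacement of a labelled ligand from prostaglandin D2 receptor 2 (Homo sapiens) (a higher number here means a weaker inhibitor, a lower number a stronger inhibitor), compound 1 gives 1500 nM, the highest of the three numbers shown. Compound 3, at 810 nM, sits nearest to it and within the scatter, so nothing can be said about an order between these two. Compound 2, at 10 nM, lies far below both, well beyond the scatter; it differs from compound 1 in more than one place, so no single change can be credited for the gap.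

Compound 4 `N#Cc1ccc(-c2nc(C(c3ccc(F)cc3)c3ccc(F)cc3)sc2CC(=O)O)cc1` is the next point to settle. It keeps the core of compound 1 and changes the 4-sulfamoylphenyl to 4-cyanophenyl:
cyano in place of sulfamoyl on an aromatic carbon

Among the measured compounds shown here, no measured pair in this set carries that change, so the expectation rests on the weak standing of compound 1 alone. A modest step toward a lower number is expected, a 1.9-fold lower number from compound 1 to compound 4 (0.27 log units; within the scatter), without confidence that it clears the scatter. Compound 4 is estimated at 800 nM, with a likely range from 200 nM to 3000 nM.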

Compound 4, half-maximal inhibitory concentration: 150 nM
Estimate against measurement, compound 4: 5.3-fold (0.73 log units) above; the measured number lies below the stated range.
By their numbers in this assay, from the lowest: compound 2; then compound 4; then compounds 3 and 1 (each within the scatter of the next).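

In this assay, among the compounds shown here, the change from 4-sulfamoylphenyl to 4-cyanophenyl gives a 10-fold lower number from compound 1 to compound 4 (1.00 log units; beyond the scatter), the first comparison that differs in one place only. This position, on an aromatic carbon para to a large group, therefore affects the number, and with the rest of compound 1 held constant, a cyano group is clearly preferred to sulfamoyl. Nothing available explains the step.

With a single pair, it remains unclear whether the difference follows from the loss of the sulfamoyl group, the arrival of the cyano group, or both, and whether it carries over to the other substituents on the core. An amine, a carboxylic acid, a methoxy group or a simple chlorine at this same place would help separate these readings.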